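Cyclopropyl to pentan-3-yl at the branch carbon

This account rests on a few compounds, and the source may have more. Where it says the series, first, only, none or still open, it means among the compounds named here.

Three compounds of the shared core have numbers in a physicochemical assay for solubility, measured as kinetic solubility, at pH 2; a lower number here means a less soluble compound, a higher number a more soluble compound. Compound 1 `CC(C)[C@@H](C[C@H]1SC(=O)NC1=O)c1ccc(-c2ccc3cccc(F)c3c2)[nH]c1=O` gives 12200 nM. Compound 2 `C/C(=C1/OC(=O)NC1=O)C(c1ccc(-c2ccc3cccc(F)c3c2)[nH]c1=O)C(C)C` gives 12700 nM. Compound 3 `O=C1NC(=O)/C(=C/C(c2ccc(-c3ccc4cccc(F)c4c3)[nH]c2=O)C2CC2)O1` gives 3850 nM, the lowest of the three; compound 1 and compound 2 both stand at higher numbers, each beyond the scatter from compound 3. Compounds 1 and 2 themselves lie within the scatter of each other. No pair among these differs in a single place, so no single step can be read from the measured set.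

Compound 4 `CCC(CC)C(/C=C1\OC(=O)NC1=O)c1ccc(-c2ccc3cccc(F)c3c2)[nH]c1=O` is not yet measured. It differs from compound 3 as pentan-3-yl in place of cyclopropyl on a saturated chain carbon bound to an aromatic carbon and a double-bonded chain carbon. Among the compounds with values here, the chain that enters carries more carbon than the ring that leaves, and no measured pair shows what this exchange does at this position, so the expectation rests on compound 3 alone.

With compound 3 at 3850 nM as the only anchor, compound 4 is estimated at 2800 nM, with a range from 900 nM to 8500 nM. The step expected is a 1.4-fold lower number from compound 3 to compound 4 (0.14 log units; within the scatter), a modest move downward that may still fall within the scatter, with the direction to be confirmed by the measurement.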

Compound 4, solubility: 3680 nM
The estimate for compound 4 lay 1.3-fold (0.12 log units) below the measured number; low and high end bracket the measured number.
By their numbers in this assay, from the lowest: compounds 4 and 3 (each within the scatter of the next); then compounds 1 and 2 (each within the scatter of the next).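

In this assay, within the data shown here, pentan-3-yl in place of cyclopropyl on a saturated chain carbon bound to an aromatic carbon and a double-bonded chain carbon gives a 1.0-fold lower number from compound 3 to compound 4 (0.02 log units; within the scatter), the first step that can be read at a single place. For this one pair, the read-out does not separate the three-membered carbon ring from the open chain of 5 carbon atoms, so neither removing the ring nor adding carbon count leaves a visible mark here, though a single pair sets no rule for the position. Nothing at hand bears on the origin of this result.

Going by these compounds, both groups compared at this position are all-carbon and carry no hydrogen-bond donors or acceptors, so it remains open whether an amine or a carboxylic acid on the same carbon would shift the number beyond the scatter. On these data alone, the steps from compound 3 or compound 4 to compound 1 and compound 2 cannot be read, as those compounds differ in more than one place, and whether this result carries over to the other forms of the series also remains open.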